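Cyano for Chloro: Expected Potency of Compound 3

The source may report more compounds than this note shows. Statements on the series, on what has been measured and on what is new or still open speak of the compounds shown alone.

Compound 1 `COc1ccc(C2=NO[C@@H]3[C@H](CO)C[C@H](CO)[C@H]23)cc1OC` and compound 2 `OC[C@@H]1C[C@H](CO)[C@@H]2C(c3ccc(Cl)cc3)=NO[C@H]12` share one core and differ only on the aromatic ring. In a functional assay on PC-3 cells (Homo sapiens) for cytotoxicity, read by MTT assay, with a stated time of 48 h (a higher number here means a weaker inhibitor, a lower number a stronger inhibitor), compound 1 gives only a limit, > 50 ug/mL. Compound 2 likewise gives only a limit in this assay, > 50 ug/mL. Compound 2 thus stands at the limit of > 50 ug/mL in this assay, at which 2 of the 2 values shown sit, with no number to rank it against anything. Compound 3 `N#Cc1ccc(C2=NO[C@@H]3[C@H](CO)C[C@H](CO)[C@H]23)cc1` differs from compound 2 by cyano in place of chloro on an aromatic carbon. Going by the values given here, no measured step between compounds exists here. The step that the limit leaves unreadable from compound 2 to compound 3 is expected to be none beyond the scatter, with a limit again the likeliest outcome. Compound 3 is estimated at 60 ug/mL, between 25 ug/mL and 150 ug/mL.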

Compound 3, half-maximal inhibitory concentration: > 50 ug/mL
Compound 3: no number, only a limit; the forecaster's own chance of this, stated with the estimate: 75%; the middle value lies beyond the limit too.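

No step can be read from compound 2 to compound 3, as both give only a limit: the limit of > 50 ug/mL in this assay, at which 3 of the 3 values shown sit.

The compounds shown leave open whether cyano and chloro differ at all in this assay, and whether any aromatic substituent on the shared core gives a readable number.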